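This account rests on a few compounds, and the source may have more. Where it says the series, first, only, none or still open, it means among the compounds named here.

Values in a physicochemical assay for solubility, read by nephelometry (a higher number here means a more soluble compound, a lower number a less soluble compound), each one a limit:
Compound 1 `CC1(C)C(=O)N(c2ccc(SC(F)(F)F)cc2)C(=O)N1Cc1ccnc(N2CCNCC2)c1`: < 0.024 ug/mL
Compound 2 `CC1(C)C(=O)N(c2ccc(SC(F)(F)F)cc2)C(=O)N1Cc1ccnc(NC2CCCCC2)c1`: < 0.025 ug/mL
Compound 3 `CNC(=O)c1cc(CN2C(=O)N(c3ccc(SC(F)(F)F)cc3)C(=O)C2(C)C)ccn1`: < 0.023 ug/mL

Compound 3 has no number, only the limit < 0.023 ug/mL. Compounds 1 and 2 likewise give limits only.

Compound 4 `CNc1cc(CN2C(=O)N(c3ccc(SC(F)(F)F)cc3)C(=O)C2(C)C)ccn1` carries methylamino in place of methylcarbamoyl on an aromatic carbon, next to the ring nitrogen (methylamino in place of methylcarbamoyl on an aromatic carbon).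

Three measured steps change the group at this place: a step that the two limits leave unreadable from compound 1 to compound 2, a step that the two limits leave unreadable from compound 1 to compound 3 and a step that the two limits leave unreadable from compound 2 to compound 3. None has a readable size, so they give no measured basis for expecting a step beyond the scatter in this assay. The estimate means an at least 1.0-fold higher number from compound 3 to compound 4 (0.03 log units; that floor lies within the scatter), and a further limit is the expected report. Compound 4 is estimated at 0.025 ug/mL, with an expected range from 0.012 ug/mL to 0.2 ug/mL.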

Compound 4, solubility: 0.075 ug/mL
Compound 4: middle estimate off by 3.0-fold (0.48 log units), on the low side; the measured number falls inside the stated range.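

In this assay, going by these compounds alone, methylamino gives the first readable change at this position, with an at least 3.2-fold higher number from compound 3 to compound 4 (0.51 log units; beyond the scatter), and it also gives an at least 3.0-fold higher number from compound 2 to compound 4 (0.47 log units; beyond the scatter) and an at least 3.1-fold higher number from compound 1 to compound 4 (0.49 log units; beyond the scatter). Each of these is a floor on the size of the step, and the steps among compounds 1, 2 and 3 cannot be read. Compound 3 has only a limit: the limit of < 0.023 ug/mL in this assay, at which 1 of the 4 values shown sits.

As far as these compounds go, the full size of these steps stays open. Also open, from the compounds shown here alone, is whether an ethylamino, dimethylamino or unsubstituted amino group at this place would read like methylamino.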